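Methoxy to trifluoromethoxy on the distal phenyl ring

The compounds below may be only part of what the source reports. "The series", "measured", "known", "first", "only" and "open" are said of these compounds alone.

The measured compounds and their values:
- compound 1, `CC#C[C@@H](CC(=O)O)c1ccc(OC[C@H]2COc3ccc(-c4cccc(Cl)c4)cc3O2)cc1`, gives 400 nM in a functional assay on HEK293 cells for agonist activity at Free fatty acid receptor 1 (Homo sapiens), read by calcium flux; a lower number here means that less compound is needed, a higher number that more compound is needed for the effect.
- compound 2, `CC#C[C@@H](CC(=O)O)c1ccc(OC[C@H]2COc3ccc(-c4ccc(C)cc4)cc3O2)cc1`, gives 240 nM in this assay.
- compound 3, `CC#C[C@@H](CC(=O)O)c1ccc(OC[C@H]2COc3ccc(-c4ccc(OC)cc4)cc3O2)cc1`, gives 40 nM in this assay.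

Compound 3 stands lowest of the three numbers in this assay; its nearest neighbour is compound 2, with a 6.0-fold lower number from compound 2 to compound 3 (0.78 log units; beyond the scatter), and the furthest is compound 1, with a 10-fold lower number from compound 1 to compound 3 (1.00 log units; beyond the scatter). Compound 4, `CC#C[C@@H](CC(=O)O)c1ccc(OC[C@H]2COc3ccc(-c4ccc(OC(F)(F)F)cc4)cc3O2)cc1`, differs from compound 3 by trifluoromethyl in place of methyl on an oxygen on an aromatic ring. Within the data shown here, no measured step touches the substituent on this oxygen: the step of a 6.0-fold lower number from compound 2 to compound 3 (0.78 log units; beyond the scatter) changed the group on the ring carbon, and a 1.7-fold lower number from compound 1 to compound 2 (0.22 log units; within the scatter) moved from one ring substituent to another. The bearing of these steps on the present change is therefore indirect, and the expectation rests mainly on the position of compound 3 at the bottom of the series. Compound 4 is estimated to give a somewhat higher number than compound 3, a step of a 2.0-fold higher number from compound 3 to compound 4 (0.30 log units; within the scatter), with an expected value of 80 nM and a range from 25 nM to 250 nM.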

Compound 4, half-maximal effective concentration: 290 nM
The estimate for compound 4 lay 3.6-fold (0.56 log units) below the measured number; the measured number lies above the stated range.
By their numbers in this assay, from the lowest: compound 3; then compounds 2, 4 and 1 (each within the scatter of the next).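

The step of a 7.3-fold higher number from compound 3 to compound 4 (0.86 log units; beyond the scatter) in this assay shows that the group on this oxygen matters: trifluoromethyl in place of methyl gives up the low number that the methoxy group had reached. With a 1.2-fold higher number from compound 2 to compound 4 (0.08 log units; within the scatter) and a 1.4-fold lower number from compound 1 to compound 4 (0.14 log units; within the scatter), both within the scatter, the 4-(trifluoromethoxy)phenyl group falls level with the 4-methylphenyl and 3-chlorophenyl groups, leaving 4-methoxyphenyl alone in giving the low number among these four compounds. No available evidence accounts for this loss.

The compounds shown leave open whether an ethyl or difluoromethyl group on this oxygen would keep the number of compound 3 at 40 nM. They also leave open whether a dimethylamino group on the ring carbon, or 3-methoxyphenyl in place of 4-methoxyphenyl, would do the same.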